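Replacing the diethylaminopropyl amide chain of compound 3

The compounds below may be only part of what the source reports. "The series", "measured", "known", "first", "only" and "open" are said of these compounds alone.

In an ADME assay on L02 cells (Homo sapiens) for cytotoxicity, read by MTT assay, with a stated time of 48 h (a lower number here means a stronger inhibitor, a higher number a weaker inhibitor), compound 3 (`CCN(CC)CCCNC(=O)c1ccc(C(CC)(CC)c2ccc(OCC(O)C(C)(C)C)c(C)c2)n1CC`) gives 2500 nM, level with compound 2 (`CCN(CC)CCNC(=O)c1ccc(C(CC)(CC)c2ccc(OCC(O)C(C)(C)C)c(C)c2)n1CC`) at 2500 nM and within the scatter of compound 1 (`CCN(CC)CCCNC(=O)c1ccc(C(CC)(CC)c2ccc(OCC(=O)C(C)(C)C)c(C)c2)n1CC`) at 2300 nM. Compound 4 (`CCn1c(C(=O)N(C)CCC#N)ccc1C(CC)(CC)c1ccc(OCC(O)C(C)(C)C)c(C)c1`) carries (2-cyanoethyl)(methyl)amino in place of (3-(diethylamino)propyl)amino on a carbonyl carbon. Within the data shown here, two measured steps bear on this only in part. One is no change at the digits printed from compound 2 to compound 3 (within the scatter), which alters the same chain, and the other is a 1.1-fold higher number from compound 1 to compound 3 (0.04 log units; within the scatter), made elsewhere; both lie within the scatter. Neither removes the diethylamino group, so the direction is uncertain and a wide range is needed. The expected step is a 2.4-fold higher number from compound 3 to compound 4 (0.38 log units; beyond the scatter), towards a higher number. Compound 4 is estimated at 6000 nM, with a range of 2000 nM to 30000 nM.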

Compound 4, half-maximal inhibitory concentration: 14900 nM
Beside the measured number, compound 4's estimate is 2.5-fold (0.40 log units) below it; the range from low to high includes it.
By their numbers in this assay, from the lowest: compounds 1, 2 and 3 (each within the scatter of the next); then compound 4.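

Whereas the chain-length change on the carbonyl carbon stayed within the scatter, this replacement moves the number beyond it in this assay, with a 6.0-fold higher number from compound 3 to compound 4 (0.78 log units; beyond the scatter) and a 6.0-fold higher number from compound 2 to compound 4 (0.78 log units; beyond the scatter) as the two steps. The position therefore does respond, at least to a change that removes the diethylamino group and the amide hydrogen together. Nothing available explains the rise.

Which of these differences carries the step remains open. A (2-cyanoethyl)amino group, or a methylated amide that keeps the diethylamino group, would separate them.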